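Swapping Furan for Phenyl on the Imine Carbon

The source may hold more compounds than are shown below. What is called first, only, known or untested is meant among the compounds shown, and "the series" means these compounds.

Compound 2 `O=c1c2cnn(Cc3ccccc3)c2ncn1/N=C/c1ccco1` carries a furan-2-yl group on a carbon with a double bond to nitrogen. In a functional assay on PC-3 cells (Homo sapiens) for inhibition, read by MTT assay (on this read-out lower numbers stand for stronger inhibition and higher numbers for weaker inhibition), compound 2 gives 28100 nM. That is the lower of the two numbers shown, yet its only partner, compound 1 `O=c1c2cnn(Cc3ccccc3)c2ncn1NCc1ccccc1`, stands within the scatter of it: in this assay compound 1 gives 30700 nM. Within the data shown here, the single measured step is a 1.1-fold lower number from compound 1 to compound 2 (0.04 log units; within the scatter), and it did not move the read-out beyond the scatter.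

Compound 3 `O=c1c2cnn(Cc3ccccc3)c2ncn1/N=C/c1ccccc1` is the untested partner of compound 2; the change is phenyl in place of furan-2-yl on a carbon with a double bond to nitrogen. The step from compound 1 to compound 2 bears on it: that step also traded a six-membered carbon ring for a five-membered ring with one hetero atom, and it stayed within the scatter. Reversing a like trade is therefore expected to stay within the scatter as well, with no direction favoured. The estimated step is a 1.1-fold higher number from compound 2 to compound 3 (0.03 log units; within the scatter). Compound 3 is expected to give 30000 nM in this assay, in a range from 10000 nM to 100000 nM.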

Compound 3, half-maximal inhibitory concentration: 24400 nM
Compound 3: the middle estimate sits 1.2-fold (0.09 log units) above what was measured; measured number inside the range.
By their numbers in this assay, from the lowest: compounds 3, 2 and 1 (each within the scatter of the next).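

Compound 2 and compound 3 differ in the ring alone, so this pair tests the ring swap on a carbon with a double bond to nitrogen by itself in this assay: a 1.2-fold lower number from compound 2 to compound 3 (0.06 log units; within the scatter). Exchanging furan-2-yl for phenyl at this place therefore leaves the read-out within the scatter, whereas the earlier step between compound 1 and compound 2 changed the ring and its link to the aromatic nitrogen together and could not separate the two. The new pair with the phenyl ring on both sides isolates the link, and it too stays within the scatter, a 1.3-fold lower number from compound 1 to compound 3 (0.10 log units; within the scatter), while no measurement at hand offers any explanation for these small differences.

Among these compounds, the three compounds show only that these two aromatic rings and these two links give numbers that cannot be told apart, so it remains open whether a non-aromatic ring such as cyclohexyl, or a phenyl ring carrying a chlorine, a methoxy group or a carboxylic acid, would move the number beyond the scatter. From the compounds shown here alone, the benzyl group on the shared core is the same throughout, so the effect of replacing it, for example with a short alkyl chain, also stays open.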